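This account rests on a few compounds, and the source may have more. Where it says the series, first, only, none or still open, it means among the compounds named here.

The study measures cytotoxicity in an ADME assay on BaF3 cells (Mus musculus) for cytotoxicity (a lower number here means that less compound is needed, a higher number that more compound is needed for the effect), for a small set of compounds that share one core. Compound 1 `NS(=O)(=O)c1ccc(-c2cc(Nc3ccc(OC(F)(F)F)cc3)ncn2)cc1` carries a sulfonamide-bearing phenyl on that core. In this assay compound 1 gives only a limit, > 10000 nM. Compound 2 `FC(F)(F)Oc1ccc(Nc2ncnc3c2cnn3C2CCCCC2)cc1` carries a cyclohexyl on the five-membered ring of its fused system, and in this assay compound 2 gives 9300 nM. Within the data shown here, that is the only actual number in the set, the other result being (the limit of > 10000 nM in this assay, at which 1 of the 2 values shown sits), so compound 2 cannot be ranked against anything.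

Compound 3 `CCn1ncc2c(Nc3ccc(OC(F)(F)F)cc3)ncnc21` is the next compound to be measured in this assay. It differs from compound 2 by ethyl in place of cyclohexyl on an aromatic nitrogen. Among the measured compounds shown here, no measured step is available to anchor this change. Given that compound 2 gives 9300 nM, the step from compound 2 to compound 3 is expected to be small, a 1.6-fold higher number from compound 2 to compound 3 (0.21 log units; within the scatter), and likely within the scatter or slightly toward a higher number. Compound 3 is therefore estimated at 15000 nM, with a range from 6000 nM to 40000 nM, and a real chance that only a limit is reported.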

Compound 3, half-maximal effective concentration: > 10000 nM
Compound 3: a limit, no number; the forecaster's own chance of this, stated with the estimate: 60%; the middle value does not contradict the limit.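

Ethyl in place of cyclohexyl on an aromatic nitrogen gives the first step that can be read at this position in this assay, an at least 1.0-fold higher number from compound 2 to compound 3 (0.03 log units; that floor lies within the scatter). That step is only a floor and it lies within the scatter, so it does not show that the change moves the number at all; it does show that removing the six-membered non-aromatic ring at this position brings no lower number, and that a value below the limit of the assay is not kept once ethyl stands there. How far the number really rises cannot be told, because the result for compound 3 is a limit and not a number, as is most of the set: the limit of > 10000 nM in this assay, at which 2 of the 3 values shown sit.

The compounds shown leave open how a longer chain such as n-butyl, a phenyl ring or a chain ending in an amine on this aromatic nitrogen would read in this assay. They also leave open whether any group at this position gives a number clearly lower than that of compound 2.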